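Methylamino in place of methyl: compound 3 to compound 4

The source may hold more compounds than are shown below. What is called first, only, known or untested is meant among the compounds shown, and "the series" means these compounds.

Compound 1 `COc1ccccc1OCC1SCCN1C(=O)CSC` gives 21 mg/kg
Compound 2 `COc1ccccc1OCC1SCCN1C(=O)C(C)(C)C` gives 24 mg/kg
Compound 3 `COc1ccccc1OCC1SCCN1C(=O)CC(C)=O` gives 26 mg/kg

In a functional assay on the whole organism (trachea) for inhibition, with Cavia porcellus as the target (on this read-out lower numbers stand for an effect already at smaller amounts and higher numbers for an effect only at larger amounts of compound), compound 3 gives 26 mg/kg and stands level with the other two compounds: a 1.2-fold higher number from compound 1 to compound 3 (0.09 log units; within the scatter) and a 1.1-fold higher number from compound 2 to compound 3 (0.03 log units; within the scatter) both lie within the scatter. Compound 4 `CNC(=O)CC(=O)N1CCSC1COc1ccccc1OC` carries methylamino in place of methyl on a carbonyl carbon. The third measured step, a 1.1-fold higher number from compound 1 to compound 2 (0.06 log units; within the scatter), also stays within the scatter, so changes to the group on the carbonyl have so far shifted nothing measurable. Within the data shown here, none of these steps introduces methylamino, so the data hold no direct precedent. No step beyond the scatter is expected, and the estimated step in this assay is a 1.0-fold lower number from compound 3 to compound 4 (0.02 log units; within the scatter) for now. The estimate for compound 4 is 25 mg/kg, with an expected range from 11 mg/kg to 55 mg/kg when measured.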

Compound 4, dose for half-maximal effect: 22 mg/kg
Compound 4: middle estimate off by 1.1-fold (0.06 log units), on the high side; the measured number falls inside the stated range.
By their numbers in this assay, from the lowest: compounds 1, 4, 2 and 3 (each within the scatter of the next).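

In this assay, methylamino in place of methyl on a carbonyl carbon brings in a hydrogen-bond donor, which compounds 1, 2 and 3 do not carry, yet the change stays within the scatter: a 1.2-fold lower number from compound 3 to compound 4 (0.07 log units; within the scatter). The other two steps, a 1.1-fold lower number from compound 2 to compound 4 (0.04 log units; within the scatter) and a 1.0-fold higher number from compound 1 to compound 4 (0.02 log units; within the scatter), also stay within it, so no change of the group on the carbonyl among these four compounds has shifted the number measurably. Nothing available explains this absence of change. From the compounds shown here alone, whether a carboxylic acid, a basic amine or a longer chain at this position would move the number beyond the scatter remains open.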